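The source may hold more compounds than are shown below. What is called first, only, known or untested is meant among the compounds shown, and "the series" means these compounds.

Compound 1 `NC[C@@H]1CCCc2cc(S(=O)(=O)c3cccc(O)c3)ccc21` is the stronger of the two compounds measured in an assay on isolated protein for displacement of a labelled ligand from 5-hydroxytryptamine receptor 6 (Homo sapiens); on this read-out higher numbers stand for weaker inhibition and lower numbers for stronger inhibition: compound 1 gives 0.251 nM, whereas compound 2 `CS(=O)(=O)c1cccc(S(=O)(=O)c2ccc3c(c2)CCC[C@H]3CN)c1` gives 3.98 nM. Among the measured compounds shown here, the one step recorded so far, a 16-fold higher number from compound 1 to compound 2 (1.20 log units; beyond the scatter), shows that replacing the hydroxy on the aromatic ring of compound 1 with methylsulfonyl costs a good deal of affinity. Compound 3 `NC[C@@H]1CCCc2cc(S(=O)(=O)Cc3ccccc3)ccc21` differs from compound 1 in another way: benzyl in place of 3-hydroxyphenyl on a sulfonyl sulfur. This change removes the hydroxy as well, and additionally inserts a saturated carbon between the sulfonyl sulfur and the ring. For the measured compounds named here, no measured step matches the second part of this change, so the only guide is the loss seen when the hydroxy was replaced in compound 2, which gave a 16-fold higher number from compound 1 to compound 2 (1.20 log units; beyond the scatter). On that basis a weakening of moderate size is expected for compound 3, roughly a 12-fold higher number from compound 1 to compound 3 (1.08 log units; beyond the scatter). The estimate for compound 3 in this assay is therefore 3 nM, with a plausible range from 0.6 nM to 15 nM.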

Compound 3, inhibition constant: 158 nM
The estimate for compound 3 lay 53-fold (1.72 log units) below the measured number, and the stated range ends below it.
By their numbers in this assay, from the lowest: compound 1; then compound 2; then compound 3.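

Among the compounds shown here, the group on the sulfonyl sulfur turns out to matter far more than the single earlier step suggested: in this assay, benzyl in place of 3-hydroxyphenyl gives a 630-fold higher number from compound 1 to compound 3 (2.80 log units; beyond the scatter), a larger step than a 16-fold higher number from compound 1 to compound 2 (1.20 log units; beyond the scatter). The exchange leaves the number of heavy atoms unchanged and keeps a six-membered aromatic ring of carbon only, so affinity at this position is not set by the size of the group or by the presence of such a ring alone. Nothing available explains why this change costs so much.

The compounds shown do not tell how much of the loss belongs to the missing hydroxy and how much to the change from an aryl to a benzyl group. A plain phenyl and a 3-hydroxybenzyl on the sulfonyl sulfur would separate the two, and a 3-aminophenyl would test whether another group can stand in for the hydroxy.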